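The source may hold more compounds than are shown below. What is called first, only, known or untested is meant among the compounds shown, and "the series" means these compounds.

In a functional assay on PC-3 cells (Homo sapiens) for inhibition, read by sulforhodamine B assay, with a stated time of 48 h (a higher number here means a weaker inhibitor, a lower number a stronger inhibitor), compound 1 (`COc1cc2c(cc1CC=C(C)C)/C(=N/NC(N)=O)C[C@@H](c1ccc(O)cc1)O2`) gives 27700 nM and compound 2 (`COc1ccc([C@@H]2C/C(=N/OCc3cn(-c4ccccc4CO)nn3)c3cc(CC=C(C)C)c(OC)cc3O2)cc1`) gives 26600 nM. For the measured compounds named here, these two values lie within the scatter of each other, so the numbers do not separate compound 1 from the only other measured compound. Compound 3 (`COc1cc2c(cc1CC=C(C)C)/C(=N/O)C[C@@H](c1ccc(O)cc1)O2`) has hydroxy in place of ureido on a double-bonded nitrogen. Going by the values given here, no measured pair isolates this change, so no step beyond the scatter is expected in this assay, and no direction is firmly expected. The expected step, a 1.3-fold lower number from compound 1 to compound 3 (0.10 log units; within the scatter), is an estimate that stays small. For compound 3 the estimated value is 22000 nM, with an expected range from 9000 nM to 50000 nM.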

Compound 3, half-maximal inhibitory concentration: 31600 nM
The estimate for compound 3 lay 1.4-fold (0.16 log units) below the measured number, within the range that was stated.
By their numbers in this assay, from the lowest: compounds 2, 1 and 3 (each within the scatter of the next).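

In this assay, for the compounds shown here, hydroxy in place of ureido on a double-bonded nitrogen gives a 1.1-fold higher number from compound 1 to compound 3 (0.06 log units; within the scatter), the first single-place comparison. At this position, replacing ureido (4 heavy atoms) with hydroxy (1 heavy atom) therefore produces no step beyond the scatter. Nothing available explains this result.

From the compounds shown here alone, whether an amine or a longer chain ending in a carboxylic acid on this nitrogen would shift the number beyond the scatter in this assay remains open. Going by these compounds, the effect of changes elsewhere on the shared core also remains open.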